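Swapping a Nitrile for a Phenyl Ring

A few compounds are considered here, and "the series" means these few. Any claim that something is new, unique, unknown or untested is made for them only; others in the source may bear on it.

Compound 1 `Cc1ccc(C(=O)Nc2cccc(-c3oc4cc(-c5ccc(F)cc5)ccc4c(=O)c3O)c2)cc1`, compound 2 `Cc1cc(C(=O)Nc2cccc(-c3oc4cc(-c5ccc(F)cc5)ccc4c(=O)c3O)c2)ccc1F` and compound 3 `N#Cc1ccc(C(=O)Nc2cccc(-c3oc4cc(-c5ccc(F)cc5)ccc4c(=O)c3O)c2)cc1` share one core and differ only in the group on the amide's aromatic ring. In a functional assay on HeLa cells (Homo sapiens) for antiproliferative activity, read by CCK-8 assay, with a stated time of 72 h (a higher number here means a weaker inhibitor, a lower number a stronger inhibitor), compound 1 gives 6190 nM, compound 2 gives 18900 nM and compound 3 gives 23300 nM, the highest of the three numbers, though close to compound 2. Compound 4 `O=C(Nc1cccc(-c2oc3cc(-c4ccc(F)cc4)ccc3c(=O)c2O)c1)c1ccc(-c2ccccc2)cc1` is not yet measured; it differs from compound 3 by phenyl in place of cyano on an aromatic carbon. For the measured compounds named here, the steps that bear on this are a 3.8-fold higher number from compound 1 to compound 3 (0.58 log units; beyond the scatter) and a 1.2-fold higher number from compound 2 to compound 3 (0.09 log units; within the scatter), both exchanges at the same aromatic carbon. Since cyano gave the highest number, a phenyl in its place is expected to bring a modest step back toward compound 1, with much uncertainty. Compound 4 is therefore estimated at 10000 nM, between 3000 nM and 40000 nM, the expected step being a 2.3-fold lower number from compound 3 to compound 4 (0.37 log units; beyond the scatter).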

Compound 4, half-maximal inhibitory concentration: > 100000 nM
Compound 4 gave a limit, no number (the forecaster's own chance of this, stated with the estimate: 5%); at least 10-fold (1.00 log units) between middle value and limit.
By their numbers in this assay, from the lowest: compound 1; then compounds 2 and 3 (each within the scatter of the next). At a limit, above all of these: compound 4.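

Compound 4 gives a limit, not a number: the limit of > 100000 nM in this assay, at which 1 of the 4 values shown sits.

Earlier exchanges on this aromatic carbon moved the number only modestly, but the six-atom phenyl brings much larger steps: an at least 4.2-fold higher number from compound 3 to compound 4 (0.63 log units; beyond the scatter), an at least 5.2-fold higher number from compound 2 to compound 4 (0.72 log units; beyond the scatter) and an at least 16-fold higher number from compound 1 to compound 4 (1.20 log units; beyond the scatter). The position therefore accepts methyl and cyano with activity still measurable, while 4-phenylphenyl on the amide carbonyl takes the compound out of the measurable range.

What lies behind this drop cannot be told from these compounds. As far as these compounds go, whether a methoxy, an amine or a cyclopropyl at this carbon would stay near compound 1 remains open.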